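The source may report more compounds than this note shows. Statements on the series, on what has been measured and on what is new or still open speak of the compounds shown alone.

In a functional assay on SMMC-7721 cells (Homo sapiens) for cytotoxicity, read by MTT assay, with a stated time of 72 h (on this read-out higher numbers stand for weaker inhibition and lower numbers for stronger inhibition), compound 1 `O=C1C(=Cc2ccc(O)cc2)C(=O)N(c2ccc(Cl)cc2)N1c1ccc(Cl)cc1` gives 20600 nM, and compound 3 `O=C1C(=Cc2cccc(Cl)c2)C(=O)N(c2ccc(Cl)cc2)N1c1ccc(Cl)cc1` gives 20200 nM. Compound 2 `CN(C)c1ccc(C=C2C(=O)N(c3ccc(Cl)cc3)N(c3ccc(Cl)cc3)C2=O)cc1` reaches only a limit of the assay, > 128000 nM. Compound 3 therefore shares the low end of these results with compound 1, since the step is a 1.0-fold lower number from compound 1 to compound 3 (0.01 log units; within the scatter). Compound 4 `COc1ccc(C=C2C(=O)N(c3ccc(Cl)cc3)N(c3ccc(Cl)cc3)C2=O)cc1OC` changes one group of compound 3: 3,4-dimethoxyphenyl in place of 3-chlorophenyl on a double-bonded chain carbon bound to a double-bonded ring carbon. Two measured swaps at this place bear on it. One is that same step within the scatter, and the other is an at least 6.3-fold lower number from compound 2 to compound 3 (0.80 log units; beyond the scatter). Like compound 2, compound 4 has neither hydroxy nor chlorine on this ring, so a modest move towards weaker inhibition is expected, with an expected step of a 2.0-fold higher number from compound 3 to compound 4 (0.30 log units; within the scatter). For compound 4, the estimated value is 40000 nM, within an expected range of 14000 nM to 128000 nM.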

Compound 4, half-maximal inhibitory concentration: > 128000 nM
Compound 4 ended at the assay's limit (the forecaster's own chance of this, stated with the estimate: 20%); middle value at least 3.2-fold (0.50 log units) away from the limit.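

At this position, a second ring with neither hydroxy nor chlorine also weakens inhibition in this assay: an at least 6.3-fold higher number from compound 3 to compound 4 (0.80 log units; beyond the scatter), and an at least 6.2-fold higher number from compound 1 to compound 4 (0.79 log units; beyond the scatter). The loss is therefore not confined to the 4-(dimethylamino)phenyl of compound 2, and among these compounds only compound 1 and compound 3, which carry hydroxy or chlorine on this ring, give readable values. The result for compound 4 is a limit, so its step from compound 2 cannot be read: the limit of > 128000 nM in this assay, at which 2 of the 4 values shown sit.

Still open, from the compounds shown here alone, is whether a single methoxy, a primary amine or a carboxylic acid on this ring would give a readable value.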